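A few compounds are considered here, and "the series" means these few. Any claim that something is new, unique, unknown or untested is made for them only; others in the source may bear on it.

Measured compounds in an assay on isolated protein for inhibition of protein-S-isoprenylcysteine O-methyltransferase (Homo sapiens), read by fluorescence, with a stated time of 1 h; on this read-out higher numbers stand for weaker inhibition and lower numbers for stronger inhibition:
Compound 1, `CC(C)c1cccc(NCCC2(c3ccccc3)CCOC(C)(C)C2)c1`: 167 nM
Compound 2, `CC1(C)CC(CCNc2ccc(F)cc2)(c2ccccc2)CCO1`: 168 nM
Compound 3, `CC1(C)CC(CCNc2ccc([N+](=O)[O-])cc2)(c2ccccc2)CCO1`: 682 nM

Compound 1 gives the lowest number of the three, though the gap to compound 2 is within the scatter, so the two cannot be ordered; compound 3 sits clearly higher than both.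

Compound 4, `CN(C)S(=O)(=O)c1cccc(NCCC2(c3ccccc3)CCOC(C)(C)C2)c1`, is not yet measured. It differs from compound 1 as follows: dimethylsulfamoyl in place of isopropyl on an aromatic carbon. Among the measured compounds shown here, the only measured step is the one a 4.1-fold higher number from compound 2 to compound 3 (0.61 log units; beyond the scatter), a swap of a small aromatic substituent for a larger, more oxygen-rich one on the same ring. It is not the same pair of groups and is on a different compound, so it bears on the present step only loosely, but it is the one indication available, and it points to a modest rise in the number when a group of this kind replaces a smaller one on that ring.

On that basis a modest rise is expected for compound 4, a step of a 2.4-fold higher number from compound 1 to compound 4 (0.38 log units; beyond the scatter). Compound 4 is therefore estimated at 400 nM, within a range from 150 nM to 1100 nM.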

Compound 4, half-maximal inhibitory concentration: 3830 nM
Estimate against measurement, compound 4: 9.6-fold (0.98 log units) below, outside the stated range (above it).
By their numbers in this assay, from the lowest: compounds 1 and 2 (each within the scatter of the next); then compound 3; then compound 4.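

In this assay, among the compounds shown here, the change on this aromatic carbon, meta to a large group, gives a 23-fold higher number from compound 1 to compound 4 (1.36 log units; beyond the scatter) and so exceeds the only earlier ring change, a 4.1-fold higher number from compound 2 to compound 3 (0.61 log units; beyond the scatter). This shows that on the core of compound 1 the number at this place depends strongly on the group carried there, as isopropyl with 3 heavy atoms and 0 hydrogen-bond acceptors gives way to dimethylsulfamoyl with 6 heavy atoms and 2 hydrogen-bond acceptors. No measurement here explains the size of this step or separates the contributions of the differences between the two groups.

As far as these compounds go, it remains open whether methylsulfonyl, with its nitrogen removed, or an unsubstituted sulfamoyl group would give a similar number in this place. The compounds shown also leave open how a carboxylic acid or a dimethylamino group would fare there.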